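A Fluorine Shift on the Benzyl Group

The source may hold more compounds than are shown below. What is called first, only, known or untested is meant among the compounds shown, and "the series" means these compounds.

In a functional assay on DU-145 cells (Homo sapiens) for inhibition, read by trypan blue exclusion, with a stated time of 96 h (a higher number here means a weaker inhibitor of growth, a lower number a stronger inhibitor of growth), the measured compounds give these values:
compound 1 `COc1ccccc1/C=C(/SCc1ccc(Cl)cc1)C(=O)c1ccc(Cl)cc1` gives 1000 nM
compound 2 `Cc1ccsc1/C=C(/SCc1ccccc1F)C(=O)c1ccc(Cl)cc1` gives 50000 nM
compound 3 `COc1ccccc1/C=C(/SCc1ccc(F)cc1)C(=O)c1ccc(Cl)cc1` gives 10000 nM

On these numbers compound 3 stands between compound 1 and compound 2. Compound 4 `COc1ccccc1/C=C(/SCc1ccccc1F)C(=O)c1ccc(Cl)cc1` follows from compound 3 by one change (2-fluorophenyl in place of 4-fluorophenyl on a saturated chain carbon bound to a sulfur), with 2-fluorophenyl in place of 4-fluorophenyl on a saturated chain carbon bound to a sulfur. For the measured compounds named here, the one measured step (a 10-fold higher number from compound 1 to compound 3 (1.00 log units; beyond the scatter)) put fluoro in place of chloro on an aromatic carbon. That is a different change, so it bears only loosely here. Compound 2 also holds 2-fluorophenyl and gives 50000 nM but differs elsewhere too, which hints weakly towards a higher number. The expected step is small (a 1.5-fold higher number from compound 3 to compound 4 (0.18 log units; within the scatter)) and not beyond the scatter. The estimate for compound 4 is 15000 nM with an expected range from 4000 nM to 50000 nM around that figure.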

Compound 4, concentration for 50% growth inhibition: 10000 nM
Compound 4: the middle estimate sits 1.5-fold (0.18 log units) above what was measured, within the range that was stated.
By their numbers in this assay, from the lowest: compound 1; then compounds 3 and 4 (each within the scatter of the next); then compound 2.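

In this assay, putting 2-fluorophenyl in place of 4-fluorophenyl on a saturated chain carbon bound to a sulfur gives no change at the digits printed from compound 3 to compound 4 (within the scatter) and so shows that the number does not respond to this shift of the fluorine. Putting 2-fluorophenyl in place of 4-chlorophenyl gives a 10-fold higher number from compound 1 to compound 4 (1.00 log units; beyond the scatter) and matches the step already seen with 4-fluorophenyl, while 2-methoxyphenyl in place of 3-methylthiophen-2-yl gives a 5.0-fold lower number from compound 2 to compound 4 (0.70 log units; beyond the scatter) with the 2-fluorophenyl held fixed. Nothing measured here offers an explanation for these steps. On these data alone, how a 2-chlorophenyl, a plain phenyl or an amine would read at this place remains open.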